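Pyridyl to Dimethoxyphenyl Ketone Swap in Chalcone Series

The compounds below may be only part of what the source reports. "The series", "measured", "known", "first", "only" and "open" are said of these compounds alone.

For the measured compounds named here, compound 2 `O=C(/C=C/c1cn(-c2ccccc2)nc1-c1cccnc1)c1ccccn1` is one of two compounds measured in a functional assay on Huh-7 cells (Homo sapiens) for inhibition, read by sulforhodamine B assay, with a stated time of 72 h; a lower number here means a stronger inhibitor, a higher number a weaker inhibitor. In this assay compound 2 gives 6400 nM, and compound 1 `COc1cc(OC)c(C(=O)/C=C/c2cn(-c3ccccc3)nc2-c2ccsc2)c(OC)c1` gives 6100 nM, a gap within the scatter. Compound 3 `COc1ccc(C(=O)/C=C/c2cn(-c3ccccc3)nc2-c2cccnc2)cc1OC` has not yet been measured. It differs from compound 2 in one place: 3,4-dimethoxyphenyl in place of pyridin-2-yl on a carbonyl carbon. No step of this kind has been measured among these compounds, so the change is expected to stay within the scatter, with a step from a 1.3-fold lower number from compound 2 to compound 3 (0.11 log units; within the scatter) expected. For compound 3 the estimate in this assay is 5000 nM, within 2000 nM to 15000 nM.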

Compound 3, half-maximal inhibitory concentration: 3100 nM
Compound 3: the middle estimate sits 1.6-fold (0.21 log units) above what was measured, within the range that was stated.
By their numbers in this assay, from the lowest: compounds 3, 1 and 2 (each within the scatter of the next, the first and the last beyond it).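

In this assay, for the compounds shown here, the change from pyridin-2-yl to 3,4-dimethoxyphenyl on a carbonyl carbon gives a 2.1-fold lower number from compound 2 to compound 3 (0.31 log units; beyond the scatter) and is the only step measured at this position. It shows that this position accepts the larger carbon-only ring without loss and that the number responds modestly to the swap. Nothing measured here accounts for the step. The compounds shown leave open how a plain phenyl, a phenyl with a single methoxy or an aminophenyl would compare on this carbonyl carbon. So whether the step belongs to the two methoxy groups or to the loss of the ring nitrogen stays unsettled.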